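The compounds below may be only part of what the source reports. "The series", "measured", "known", "first", "only" and "open" are said of these compounds alone.

Measured so far in a functional assay on OVCAR-3 cells (Homo sapiens) for antiproliferative activity; a lower number here means that less compound is needed, a higher number that more compound is needed for the effect:
compound 1 `CC(C)(C)NS(=O)(=O)c1cccc(NC(=O)c2cccnc2N2CCC3(CC2)CC3)c1` — 840 nM
compound 2 `CC(C)(C)NS(=O)(=O)c1cccc(NC(=O)c2ccc(NC(C)(C)CO)nc2N2CCC3(CC2)CC3)n1` — 42 nM
compound 3 `O=C(Nc1cccc(S(=O)(=O)C2CCCC2)c1)c1cccnc1N1CCC(F)(F)CC1` — 4780 nM

Compound 1 stands second highest of the three numbers in this assay: compound 2 gives a lower number and compound 3 a higher one, both gaps beyond the usual scatter. Compound 4 `CC(C)S(=O)(=O)c1cccc(NC(=O)c2cccnc2N2CCC3(CC2)CC3)c1` differs from compound 1 in one place, (isopropyl in place of (tert-butyl)amino on a sulfonyl sulfur). Within the data shown here, no measured pair shows this change on its own, so its size is untested in this set. A modest rise in the number is expected, a 1.8-fold higher number from compound 1 to compound 4 (0.25 log units; within the scatter), of a size that may not clearly exceed the scatter. Compound 4 is therefore estimated at 1500 nM, with a range from 400 nM to 6000 nM.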

Compound 4, half-maximal effective concentration: 4480 nM
The estimate for compound 4 lay 3.0-fold (0.48 log units) below the measured number; measured number inside the range.
By their numbers in this assay, from the lowest: compound 2; then compound 1; then compounds 4 and 3 (each within the scatter of the next).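

In this assay, isopropyl in place of (tert-butyl)amino on a sulfonyl sulfur gives a 5.3-fold higher number from compound 1 to compound 4 (0.73 log units; beyond the scatter), so this position responds to substitution on the core of compound 1. The change removes a hydrogen-bond donor and also reduces the heavy-atom count, and this single step cannot separate the two differences. No measured evidence bears on the origin of the step. Open, as far as these compounds go, is whether tert-butyl directly on the sulfonyl sulfur, or a smaller amine such as methylamino, would stay nearer compound 1.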